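The source may report more compounds than this note shows. Statements on the series, on what has been measured and on what is new or still open speak of the compounds shown alone.

Working notes on the series, read in a functional assay on MCF7 cells (Homo sapiens) for cytotoxicity; a higher number here means a weaker inhibitor, a lower number a stronger inhibitor. Compound 1 `C=C/C=C\[C@H](C)[C@H](OC(N)=O)[C@@H](C)[C@H](O)[C@@H](C)C/C(C)=C\[C@H](C)[C@@H](O)[C@@H](C)/C=C\CCc1ccc(C)c(F)c1` gives 1000 nM and compound 2 `C=C/C=C\[C@H](C)[C@H](OC(N)=O)[C@@H](C)[C@H](O)[C@@H](C)C/C(C)=C\[C@H](C)[C@@H](O)[C@@H](C)/C=C\CCc1ccc(C)c(O)c1` gives 770 nM. These two numbers lie within the scatter of each other, so compound 2 stands with compound 1 and no order can be read between them. The next structure is compound 3 `C=C/C=C\[C@H](C)[C@H](OC(N)=O)[C@@H](C)[C@H](O)[C@@H](C)C/C(C)=C\[C@H](C)[C@@H](O)[C@@H](C)/C=C\CCc1cccc(Cl)c1`, and the change is 3-chlorophenyl in place of 3-hydroxy-4-methylphenyl on a saturated chain carbon, two bonds along the chain from a double-bonded chain carbon: 3-chlorophenyl in place of 3-hydroxy-4-methylphenyl, on a saturated chain carbon, two bonds along the chain from a double-bonded chain carbon. Within the data shown here, the only measured step to draw on is a 1.3-fold lower number from compound 1 to compound 2 (0.11 log units; within the scatter), hydroxy in place of fluoro on an aromatic carbon, and it stays within the scatter. Among the measured compounds shown here, no measured compound carries the 3-chlorophenyl group, so this guide is indirect. With that single step in hand, no change beyond the scatter is expected in this assay. The estimate for compound 3 is 800 nM, with an expected range from 300 nM to 2500 nM. The expected step is a 1.0-fold higher number from compound 2 to compound 3 (0.02 log units; within the scatter).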

Compound 3, half-maximal inhibitory concentration: 400 nM
Compound 3: middle estimate off by 2.0-fold (0.30 log units), on the high side; low and high end bracket the measured number.
By their numbers in this assay, from the lowest: compounds 3, 2 and 1 (each within the scatter of the next, the first and the last beyond it).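

In this assay, the change from 3-hydroxy-4-methylphenyl to 3-chlorophenyl on the saturated chain carbon gives a 1.9-fold lower number from compound 2 to compound 3 (0.28 log units; within the scatter), so compound 3 stands with compound 2 and no order can be read between them. Against the fluoro member, 3-chlorophenyl in place of 3-fluoro-4-methylphenyl gives a 2.5-fold lower number from compound 1 to compound 3 (0.40 log units; beyond the scatter), the first step in the series beyond the scatter, which shows that this aryl end can move the number when the whole group is exchanged. Nothing at hand speaks to the reason for this step.

Each exchange alters the ring at more than one point, so the part played by the chlorine cannot be separated from that of the lost methyl. From the compounds shown here alone, a 3-chloro-4-methylphenyl group would separate the two, and the effect of an amine on the ring or a longer chain to it remains open.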